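A few compounds are considered here, and "the series" means these few. Any claim that something is new, unique, unknown or untested is made for them only; others in the source may bear on it.

Within the data shown here, in an ADME assay for permeability, using PAMPA, with a stated time of 30 min, at pH 7.4 (a higher number here means that the compound crosses the layer faster, a lower number that the compound crosses the layer more slowly), compound 2 `COc1ccc(-c2ccc3c(NCCCNCc4cc(F)ccc4OC)ccnc3c2)cc1` stands at 237 10^-6 cm/s, one of only two numbers so far, while compound 1 `COc1cccc(Oc2ccc3c(NCCCNCc4cc(F)ccc4OC)ccnc3c2)c1` gives 317 10^-6 cm/s; the single measured step, a 1.3-fold lower number from compound 1 to compound 2 (0.13 log units; within the scatter), falls within the scatter. Compound 3 `COc1ccc(F)cc1CNCCCNc1ccnc2cc(CC3CCCCC3)ccc12` carries cyclohexylmethyl in place of 4-methoxyphenyl on an aromatic carbon. Among the measured compounds shown here, no measured step exchanges an aromatic ring for a non-aromatic one, so that lone step bears only loosely on this change, and it was itself no more than scatter. Compound 3 is therefore expected to give 250 10^-6 cm/s, within a range of 150 10^-6 cm/s to 400 10^-6 cm/s. The estimated step of a 1.1-fold higher number from compound 2 to compound 3 (0.02 log units; within the scatter) is expected to stay within the scatter.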

Compound 3, apparent permeability: 23 10^-6 cm/s
Compound 3: middle estimate off by 11-fold (1.04 log units), on the high side; measured number outside the range, below it.
By their numbers in this assay, from the lowest: compound 3; then compounds 2 and 1 (each within the scatter of the next).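

In this assay, this position on an aromatic carbon turns out to be able to move the number well beyond the scatter: cyclohexylmethyl in place of 4-methoxyphenyl gives a 10-fold lower number from compound 2 to compound 3 (1.01 log units; beyond the scatter), and cyclohexylmethyl in place of 3-methoxyphenoxy gives a 14-fold lower number from compound 1 to compound 3 (1.14 log units; beyond the scatter). The earlier exchange between the two groups carrying aromatic rings stayed within the scatter, so among these compounds, only the non-aromatic ring goes with a large fall. Nothing measured here accounts for that fall. Going by these compounds, whether a benzyl group would stand with compound 3 or with compound 2 remains open, which leaves the ring and its link unseparated. On these data alone, how a piperidine ring would fare at this place also remains open.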